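Swapping an Amine for a Ketone on the Pendant Ring

The compounds below may be only part of what the source reports. "The series", "measured", "known", "first", "only" and "open" are said of these compounds alone.

Measured so far:
compound 1, `CCN(c1ccc(C(C)C)cc1)c1nc(C)cc(C)n1`: > 1000 nM
compound 2, `CCN(CC)c1nc(C)nc(N(CC)c2ccc(N(C)C)cc2Br)n1`: 6 nM

In an assay on isolated protein for binding affinity to corticotropin-releasing factor receptor 1 (Homo sapiens) (a higher number here means a weaker inhibitor, a lower number a stronger inhibitor), compound 1 reaches only a limit of the assay, > 1000 nM, and this reading is not a number but (the limit of > 1000 nM in this assay, at which 1 of the 2 values shown sits). Among the compounds with values here, compound 2 gives the only actual number in this assay, 6 nM, so it stands alone and no comparison within the measured set can be drawn.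

Compound 3, `CCN(CC)c1nc(C)nc(N(CC)c2ccc(C(C)=O)cc2Br)n1`, differs from compound 2 by one change: acetyl in place of dimethylamino on an aromatic carbon. Both groups carry one acceptor, but an amine is replaced by a ketone. Within the data shown here, no step between measured compounds exists here, so the size of this change must be guessed. Binding of compound 3 is expected to be weaker than that of compound 2 by more than the usual scatter. The expected step is a 6.7-fold higher number from compound 2 to compound 3 (0.82 log units; beyond the scatter). Compound 3 is estimated at 40 nM, with a likely range from 8 nM to 300 nM.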

Compound 3, inhibition constant: 17 nM
Compound 3: the middle estimate sits 2.4-fold (0.37 log units) above what was measured; measured number inside the range.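

Within the data shown here, this is the first step that can be read in this assay: acetyl in place of dimethylamino on an aromatic carbon gives a 2.8-fold higher number from compound 2 to compound 3 (0.45 log units; beyond the scatter), a modest loss. At this place, para to a large group and meta to a bromo group, binding therefore does not need the nitrogen of the dimethylamino group, and a ketone of the same heavy-atom count keeps most of it. Nothing among the data shown explains why the step has this size.

From the compounds shown here alone, with a single change at this place, it stays open whether other groups would behave like acetyl or dimethylamino. A methoxy group, a nitrile or a carboxylic acid here would show how much this position tolerates, and a plain hydrogen would show what either group contributes.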